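The source may report more compounds than this note shows. Statements on the series, on what has been measured and on what is new or still open speak of the compounds shown alone.

Of the compounds shown here, three have numbers so far in a functional assay on HepG2 cells (Homo sapiens) for antiproliferative activity, read by sulforhodamine B assay, with a stated time of 48 h; on this read-out higher numbers stand for weaker inhibition and lower numbers for stronger inhibition. Compound 1 (`COc1cc(C=C(C(=O)/C=C/c2cccc(OC)c2OC)C(=O)/C=C/c2cccc(OC)c2OC)ccc1O`) gives 200 nM, compound 2 (`COc1cccc(/C=C/C(=O)C(=Cc2cc(OC)c(OC)c(OC)c2)C(=O)/C=C/c2cccc(OC)c2OC)c1OC`) gives 220 nM and compound 3 (`COc1cccc(C=C(C(=O)/C=C/c2cccc(OC)c2OC)C(=O)/C=C/c2cccc(OC)c2OC)c1OC`) gives 230 nM. Compound 3 therefore stands level with the other two, as all three values lie within the scatter of one another.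

The next compound is compound 4 (`COc1ccc(C=C(C(=O)/C=C/c2cccc(OC)c2OC)C(=O)/C=C/c2cccc(OC)c2OC)cc1O`), which has 3-hydroxy-4-methoxyphenyl in place of 2,3-dimethoxyphenyl on a double-bonded chain carbon bound to a double-bonded chain carbon. The same place varies among the measured compounds, so three steps bear on the change. The closest is the exchange of 4-hydroxy-3-methoxyphenyl for 2,3-dimethoxyphenyl, which gives a 1.2-fold higher number from compound 1 to compound 3 (0.06 log units; within the scatter). The exchange for 3,4,5-trimethoxyphenyl gives a 1.1-fold higher number from compound 1 to compound 2 (0.04 log units; within the scatter), and the exchange of that group for 2,3-dimethoxyphenyl gives a 1.0-fold higher number from compound 2 to compound 3 (0.02 log units; within the scatter). All three steps lie within the scatter. Among the measured compounds shown here, no measured compound carries 3-hydroxy-4-methoxyphenyl itself, so this precedent is indirect.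

No step beyond the scatter is therefore expected in this assay. The expected step is a 1.0-fold lower number from compound 3 to compound 4 (0.02 log units; within the scatter). For compound 4 the estimated value is 220 nM, with an expected range of 110 nM to 450 nM.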

Compound 4, half-maximal inhibitory concentration: 270 nM
Estimate against measurement, compound 4: 1.2-fold (0.09 log units) below; the range from low to high includes it.
By their numbers in this assay, from the lowest: compounds 1, 2, 3 and 4 (each within the scatter of the next).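

In this assay the place on a double-bonded chain carbon bound to a double-bonded chain carbon now has a direct reading for 3-hydroxy-4-methoxyphenyl: the exchange for 2,3-dimethoxyphenyl gives a 1.2-fold higher number from compound 3 to compound 4 (0.07 log units; within the scatter) and the exchange for 3,4,5-trimethoxyphenyl gives a 1.2-fold higher number from compound 2 to compound 4 (0.09 log units; within the scatter) so neither exchange separates the groups. The series also now holds a pair whose groups carry the same two substituents with their numbers exchanged, and 3-hydroxy-4-methoxyphenyl in place of 4-hydroxy-3-methoxyphenyl gives a 1.4-fold higher number from compound 1 to compound 4 (0.13 log units; within the scatter) so this read-out does not tell the two arrangements apart. The entering group has one hydrogen-bond donor where 2,3-dimethoxyphenyl has none, yet that difference comes with no step beyond the scatter, and no supporting measurement is available to account for the flat picture at this place.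

As far as these compounds go, all four compounds keep the rest of the shared core, so it remains open whether the flat picture holds when the other parts change. From the compounds shown here alone, it also remains open whether a phenyl carrying an amine or a carboxylic acid, or a longer chain in place of the aromatic ring, would give a step beyond the scatter at this place.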